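The compounds below may be only part of what the source reports. "The series", "measured", "known", "first", "only" and "open" are said of these compounds alone.

Of the compounds shown here, three sharing one core have been measured in a functional assay on HepG2 cells (Homo sapiens) for cytotoxicity, read by MTT assay, with a stated time of 48 h; on this read-out higher numbers stand for weaker inhibition and lower numbers for stronger inhibition. Compound 1 `COc1cc(-c2nnc3n2NC(c2ccco2)C(C(=O)c2ccc(F)c(F)c2)S3)cc(OC)c1OC` carries a 3,4-difluorophenyl group on the carbonyl carbon, and in this assay compound 1 gives 52400 nM. Compound 2 `COc1ccc(C(=O)C2Sc3nnc(-c4cc(OC)c(OC)c(OC)c4)n3NC2c2ccco2)cc1` carries a 4-methoxyphenyl group at that carbonyl. In this assay compound 2 reaches only the limit of the measurement, > 100000 nM. Compound 3 `COc1cc(-c2nnc3n2NC(c2ccco2)C(C(=O)C2CC2)S3)cc(OC)c1OC` carries a cyclopropyl group there. In this assay compound 3 likewise reaches only a limit, > 100000 nM. Compound 3 thus stands at a limit rather than a number, a position it shares with one other compound (the limit of > 100000 nM in this assay, at which 2 of the 3 values shown sit).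

The new compound, compound 4 `COc1cc(-c2nnc3n2NC(c2ccco2)C(C(=O)c2cccc(Br)c2)S3)cc(OC)c1OC`, differs from compound 3 in one place: 3-bromophenyl in place of cyclopropyl on a carbonyl carbon. Among the compounds with values here, two measured steps bear on this. The step of an at least 1.9-fold higher number from compound 1 to compound 3 (0.28 log units; that floor lies within the scatter) shows that exchanging an aromatic ring for cyclopropyl moved the read-out from a number to a limit, though its floor lies within the scatter. The step that the two limits leave unreadable from compound 2 to compound 3 cannot be read at all. Returning from cyclopropyl to an aromatic ring may therefore bring the number back near that of compound 1, or leave it at the limit. Compound 4 is estimated at 70000 nM, within a range from 25000 nM to 200000 nM, which corresponds to an expected step of an at least 1.4-fold lower number from compound 3 to compound 4 (0.15 log units; that floor lies within the scatter).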

Compound 4, half-maximal inhibitory concentration: > 100000 nM
Compound 4: only a limit was reported (the forecaster's own chance of this, stated with the estimate: 40%); middle value at least 1.4-fold (0.15 log units) away from the limit.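

Putting an aromatic ring back on the carbonyl carbon is not enough by itself to bring a number back in this assay: 3-bromophenyl joins cyclopropyl and 4-methoxyphenyl at the limit, and only compound 1, with its 3,4-difluorophenyl group, goes against this. Even that contrast remains weak, since the change from 3,4-difluorophenyl to 3-bromophenyl gives an at least 1.9-fold higher number from compound 1 to compound 4 (0.28 log units; that floor lies within the scatter), so no real difference between these two aromatic groups is established. The steps from compound 2 and from compound 3 to compound 4 cannot be read, and the assay separates few of these groups at this position because most of the results are limits rather than numbers: the limit of > 100000 nM in this assay, at which 3 of the 4 values shown sit.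

As far as these compounds go, it remains open whether the number for compound 1 depends on its fluorine atoms, which plain phenyl or a phenyl ring carrying a single fluorine on the same carbonyl carbon could test. Also open, from the compounds shown here alone, is whether a different kind of group there, such as a carboxylic acid or an amine, would give a clearly stronger result than compound 1.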